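Hydroxyl for methoxy on the styryl arm

The source may report more compounds than this note shows. Statements on the series, on what has been measured and on what is new or still open speak of the compounds shown alone.

Measured so far:
compound 1, `COc1cccc([C@H](O)[C@H]2CO[C@H](c3ccc(OC)c(OC)c3)[C@@H](C/C=C/c3ccc(OC)c(OC)c3)C2)c1`: 21200 nM
compound 2, `COc1cccc(/C=C/C[C@H]2C[C@@H]([C@@H](O)c3ccccc3)CO[C@@H]2c2ccccc2)c1`: 10900 nM
compound 3, `COc1ccc(CCC[C@H]2C[C@@H]([C@@H](O)c3ccc(OC)c(OC)c3)CO[C@@H]2c2ccc(OC)c(OC)c2)cc1OC`: 37700 nM

All three were read in a functional assay on HeLa cells (Homo sapiens) for cytotoxicity, read by WST assay, with a stated time of 48 h; a lower number here means a stronger inhibitor, a higher number a weaker inhibitor. Compound 2 holds the lowest of the three numbers in this assay; the number for compound 1 lies within the scatter of it, while compound 3 lies beyond the scatter. Compound 4, `Oc1ccccc1/C=C/C[C@H]1C[C@@H]([C@@H](O)c2ccccc2)CO[C@@H]1c1ccccc1`, is not yet measured. It differs from compound 2 in one place: 2-hydroxyphenyl in place of 3-methoxyphenyl on a double-bonded chain carbon bound to a double-bonded chain carbon. For the measured compounds named here, no measured pair in this set differs in that way, so the step has no precedent here. Given how narrow the spread of the three values is, the step of a 1.1-fold higher number from compound 2 to compound 4 (0.04 log units; within the scatter) is expected to be small, with no direction beyond the scatter. For compound 4 the expected value in this assay is 12000 nM, with a range from 5000 nM to 30000 nM.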

Compound 4, half-maximal inhibitory concentration: 21800 nM
For compound 4 the middle estimate is 1.8-fold (0.26 log units) below the measured one; low and high end bracket the measured number.
By their numbers in this assay, from the lowest: compounds 2, 1, 4 and 3 (each within the scatter of the next, the first and the last beyond it).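

In this assay, 2-hydroxyphenyl in place of 3-methoxyphenyl on a double-bonded chain carbon bound to a double-bonded chain carbon gives a 2.0-fold higher number from compound 2 to compound 4 (0.30 log units; within the scatter). This only one-place pair in the set shows that this position accepts a hydroxyl-bearing ring with no step beyond the scatter. No measured evidence bears on this result.

The step alters both the group and its place on the ring, so 3-hydroxyphenyl and 2-methoxyphenyl would be needed to separate the two. Going by these compounds, how an amine or a carboxylic acid on this ring would read remains open.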